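Phenoxy chain series: ring substituent change on compound 3

This account rests on a few compounds, and the source may have more. Where it says the series, first, only, none or still open, it means among the compounds named here.

Compound 1 `O=C(O)c1csc([C@H]2CC[C@@H]3[C@@H](CCCOc4ccccc4)[C@H](O)C[C@@H]3O2)n1` gives 10 nM in a functional assay on CHO cells for agonist activity at prostaglandin E2 receptor EP2 subtype (Homo sapiens), read by HTRF and cAMP accumulation, with a stated time of 30 min; on this read-out higher numbers stand for an effect only at larger amounts of compound and lower numbers for an effect already at smaller amounts. Compound 2 `O=C(O)c1csc([C@H]2CC[C@@H]3[C@@H](CCOc4ccccc4)[C@H](O)C[C@@H]3O2)n1` gives 1.4 nM, and compound 3 `Cc1ccc(OC[C@@H]2[C@H]3CC[C@H](c4nc(C(=O)O)cs4)O[C@H]3C[C@H]2O)cc1` gives 27 nM, the highest number of the three, with compound 1 nearest to it. The measured steps concern the chain alone: a 7.1-fold lower number from compound 1 to compound 2 (0.85 log units; beyond the scatter), a 2.7-fold higher number from compound 1 to compound 3 (0.43 log units; beyond the scatter), and a 19-fold higher number from compound 2 to compound 3 (1.29 log units; beyond the scatter). Compound 4 `O=C(O)c1csc([C@H]2CC[C@@H]3[C@@H](COc4ccccc4Cl)[C@H](O)C[C@@H]3O2)n1` keeps the chain of compound 3 and differs only at the aromatic ring: 2-chlorophenyl in place of 4-methylphenyl on an oxygen on a saturated carbon. Within the data shown here, none of the measured steps alters that ring, so they do not bear directly on this change and give no direction. The expected step is therefore none beyond the scatter, a 1.1-fold lower number from compound 3 to compound 4 (0.03 log units; within the scatter). Compound 4 is estimated at 25 nM, with a range from 6 nM to 100 nM.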

Compound 4, half-maximal effective concentration: 3.3 nM
Compound 4: the middle estimate sits 7.6-fold (0.88 log units) above what was measured; the whole stated range lies above it.
By their numbers in this assay, from the lowest: compound 2; then compound 4; then compound 1; then compound 3.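

The ring on the oxygen of the short chain is a working position: 2-chlorophenyl in place of 4-methylphenyl gives (an 8.2-fold lower number from compound 3 to compound 4 (0.91 log units; beyond the scatter)) in this assay. With this ring, the short chain no longer sits last in the series: the steps are (a 2.4-fold higher number from compound 2 to compound 4 (0.37 log units; beyond the scatter)) and (a 3.0-fold lower number from compound 1 to compound 4 (0.48 log units; beyond the scatter)). No supporting data explain the gain.

Open, as far as these compounds go, is whether the step comes from losing the methyl or from gaining the chlorine. Also open, from the compounds shown here alone, are how the 2-chlorophenyl ring reads on the longer chains of compound 1 and compound 2, and how a methoxy group on the ring would read.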